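Adding a Second Chloro to the Anilide of Compound 1

This account rests on a few compounds, and the source may have more. Where it says the series, first, only, none or still open, it means among the compounds named here.

Compound 1 `Cn1c(Cc2nn(C)c(=O)c3ccccc23)nnc1SCCCCCCCCCCC(=O)Nc1ccccc1Cl`: 15000 nM
Compound 2 `CCCOc1ccc(NC(=O)CCCCCCCSc2nnc(Cc3nn(C)c(=O)c4ccccc34)n2C)cc1`: 1600 nM

In an assay on isolated protein (Mus musculus) for inhibition of IL15-IL15 receptor (Homo sapiens), read by resazurin assay, with stated times of 30 min and 2.5 days (a higher number here means a weaker inhibitor, a lower number a stronger inhibitor), compound 1 gives 15000 nM, the higher of the two numbers, whereas compound 2 gives 1600 nM. Compound 3 `Cn1c(Cc2nn(C)c(=O)c3ccccc23)nnc1SCCCCCCCCCCC(=O)Nc1ccc(Cl)cc1Cl` differs from compound 1 by chloro in place of hydrogen on an aromatic carbon, turning the 2-chlorophenyl into a 2,4-dichlorophenyl. Within the data shown here, no measured pair shows this exact change, so the direction rests on little. A modest move toward a lower number is expected, hardly beyond the scatter. Compound 3 is estimated at 8000 nM, within 2500 nM to 25000 nM. The expected step is a 1.9-fold lower number from compound 1 to compound 3 (0.27 log units; within the scatter).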

Compound 3, half-maximal inhibitory concentration: 3300 nM
Estimate against measurement, compound 3: 2.4-fold (0.38 log units) above, within the range that was stated.
By their numbers in this assay, from the lowest: compound 2; then compound 3; then compound 1.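

In this assay, chloro in place of hydrogen on the aromatic carbon para to the large group gives a 4.5-fold lower number from compound 1 to compound 3 (0.66 log units; beyond the scatter), the only step shown between compounds that differ in one place. It shows that this position on the 2-chlorophenyl responds to substitution, with the long chain and the shared core unchanged. Nothing given here explains the step.

As far as these compounds go, it remains open whether a 4-chlorophenyl, with no second chloro, would show the same step. From the compounds shown here alone, whether fluoro, methoxy or a carboxylic acid at this position would move the number the same way also remains open.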